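A few compounds are considered here, and "the series" means these few. Any claim that something is new, unique, unknown or untested is made for them only; others in the source may bear on it.

Compound 2 `CSc1nsnc1C1CN2CCC[C@H]1C2` gives 0.14 mg/kg in a functional assay on the whole organism for inhibition, with Rattus norvegicus as the target; on this read-out higher numbers stand for an effect only at larger amounts of compound and lower numbers for an effect already at smaller amounts. Compound 3 `CCCSc1nsnc1[C@@H]1CN2CCC[C@H]1C2` gives 0.03 mg/kg in this assay. Compound 1 `CCCCSc1nsnc1[C@H]1CN2CCC[C@H]1C2` reaches only a limit in this assay, > 3 mg/kg, not a number.

Of the two numbers, compound 2 holds the higher one, and its gap to compound 3 lies beyond the usual scatter, so compound 3 acts at smaller amounts. Compound 4 `CCCCCCSc1nsnc1C1CN2CCC[C@H]1C2` differs from compound 2 by pentyl in place of hydrogen on a saturated chain carbon bound to a sulfur. Among the compounds with values here, no measured pair shows this step. Compound 1, with a butyl group, sits at the limit of > 3 mg/kg in this assay, at which 1 of the 3 values shown sits. Because of that limit of > 3 mg/kg in this assay, at which 1 of the 3 values shown sits, a much longer chain is expected to raise the number, and the step is estimated as a 36-fold higher number from compound 2 to compound 4 (1.55 log units; beyond the scatter). Compound 4 is therefore expected near 5 mg/kg, between 1 mg/kg and 30 mg/kg, with a real chance of only a limit.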

Compound 4, dose for half-maximal effect: 0.1 mg/kg
Compound 4: middle estimate off by 50-fold (1.70 log units), on the high side, and the stated range ends above it.
By their numbers in this assay, from the lowest: compound 3; then compounds 4 and 2 (each within the scatter of the next). At a limit, above all of these: compound 1.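

Putting pentyl in place of hydrogen on the saturated chain carbon bound to a sulfur, the same difference as methyl to hexyl, gives a 1.4-fold lower number from compound 2 to compound 4 (0.15 log units; within the scatter) in this assay. Within the data shown here, this is the first pair here that differs in one place only, and it shows that this position can carry a chain as long as hexyl with the dose staying within the usual scatter.

As far as these compounds go, how a still longer chain, a branched chain, or a chain ending in an amine or a carboxylic acid would behave here stays open. No pair shown separates the effect of chain length from that of the spatial arrangement of the core.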